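Series notes: from compound 2 to compound 3

A few compounds are considered here, and "the series" means these few. Any claim that something is new, unique, unknown or untested is made for them only; others in the source may bear on it.

Measured in an ADME assay on CHO cells (Cricetulus griseus) for cytotoxicity; on this read-out lower numbers stand for stronger inhibition and higher numbers for weaker inhibition:
- compound 1 `Oc1ccc(CNc2cc(Nc3cnccn3)nc(-c3ccnc(N4CCNCC4)c3)c2)cc1`: > 20000 nM (a limit)
- compound 2 `O=C(Nc1cc(Nc2cnccn2)nc(-c2ccnc(N3CCNCC3)c2)c1)C1CCNCC1`: > 20000 nM (a limit)

Compound 2 stands at > 20000 nM, which is a limit of this assay and not a number. Compound 1 reads > 20000 nM, which is also a limit. For the measured compounds named here, the series so far therefore offers only this: the limit of > 20000 nM in this assay, at which 2 of the 2 values shown sit.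

Compound 3 `O=C(Nc1cc(Nc2cnccn2)nc(-c2ccnc(N3CCNCC3)c2)c1)c1cncnc1` carries pyrimidin-5-yl in place of piperidin-4-yl on a carbonyl carbon. Going by the values given here, the one measured step that bears on this change is a step that the two limits leave unreadable from compound 1 to compound 2. Its size cannot be read, so it gives no measure of how far a change on this part of the structure moves the read-out, and no direction.

Without a readable step, no shift beyond the scatter is expected in this assay, and another limit is the likeliest report. The expected step is a number no higher from compound 2 to compound 3 (the limit leaves the size open). For compound 3 the estimated value is 20000 nM, with an expected range of 10000 nM to 40000 nM.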

Compound 3, half-maximal inhibitory concentration: > 20000 nM
Compound 3 ended at the assay's limit; the forecaster's own chance of this, stated with the estimate: 75%; the middle value sits exactly at the limit.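

In this assay compound 3 gives > 20000 nM, a limit and not a number. For the compounds shown here, its steps from compound 2 and from compound 1 therefore cannot be read, and no new step follows. Left open is how far the pyrimidin-5-yl, piperidin-4-yl or 4-hydroxybenzyl compounds lie from the one reading the series offers: the limit of > 20000 nM in this assay, at which 3 of the 3 values shown sit.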